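A few compounds are considered here, and "the series" means these few. Any claim that something is new, unique, unknown or untested is made for them only; others in the source may bear on it.

The measured compounds:

Compound 1 `O=C(NNC(=O)c1cc([N+](=O)[O-])c[nH]1)Nc1ccc([N+](=O)[O-])cc1`: 211000 nM in an ADME assay on Vero cells (Chlorocebus sabaeus) for cytotoxicity, read by MTT assay, with a stated time of 72 h; on this read-out lower numbers stand for stronger inhibition and higher numbers for weaker inhibition
Compound 2 `Cn1cc([N+](=O)[O-])cc1C(=O)NNC(=O)Nc1ccc([N+](=O)[O-])cc1`: 402000 nM in this assay
Compound 3 `O=C(NNC(=O)c1cc([N+](=O)[O-])c[nH]1)Nc1ccccc1`: 357000 nM in this assay

Compound 2 has the highest number of the three in this assay, yet its distance to compound 3 and its distance to compound 1 both lie within the scatter, so no order among them can be read from these values. The step of a 1.9-fold higher number from compound 1 to compound 2 (0.28 log units; within the scatter), methyl in place of hydrogen on an aromatic nitrogen, and the step of a 1.7-fold higher number from compound 1 to compound 3 (0.23 log units; within the scatter), hydrogen in place of nitro on an aromatic carbon, are both within the scatter as well.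

Compound 4 `Cn1cc([N+](=O)[O-])cc1C(=O)NNC(=O)Nc1ccc(Br)cc1` differs from compound 2 in one place: bromo in place of nitro on an aromatic carbon. Among the compounds with values here, no measured step exchanges nitro for bromo. The closest comparison is a 1.7-fold higher number from compound 1 to compound 3 (0.23 log units; within the scatter), which removed the nitro from the same six-membered ring of carbon only and stayed within the scatter; the step of a 1.9-fold higher number from compound 1 to compound 2 (0.28 log units; within the scatter), at another site, was also within the scatter. On this basis compound 4 is expected to move no further than the scatter, so a 1.1-fold lower number from compound 2 to compound 4 (0.06 log units; within the scatter) is the estimated step. Compound 4 is therefore estimated at 350000 nM in this assay, with a range of 150000 nM to 800000 nM.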

Compound 4, half-maximal inhibitory concentration: 602000 nM
Compound 4: the middle estimate sits 1.7-fold (0.24 log units) below what was measured; measured number inside the range.
By their numbers in this assay, from the lowest: compounds 1, 3, 2 and 4 (each within the scatter of the next, the first and the last beyond it).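

With a 1.5-fold higher number from compound 2 to compound 4 (0.18 log units; within the scatter) in this assay, this change shows that a single bromine atom can take the place of the three heavy atoms of the nitro group on the six-membered aromatic ring of carbon only, para to a large group, without a step beyond the scatter. The earlier step at this ring, from nitro to hydrogen, was taken on compound 1, which carries a hydrogen on the aromatic nitrogen, whereas this exchange was taken on compound 2, which carries a methyl there, so two different replacements of nitro on two backgrounds have now stayed within the scatter. Nothing measured here offers a reason for the size of this step or tells what the nitro group contributes in these cells.

The compounds shown leave open whether an amine or a carboxylic acid at this same place would also stay within the scatter, or whether only bromo and hydrogen do so. They also leave open whether bromo gives a similar step on compound 1, with hydrogen rather than methyl on the aromatic nitrogen.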